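Series notes: replacing the chain substituent on the shared core

This account rests on a few compounds, and the source may have more. Where it says the series, first, only, none or still open, it means among the compounds named here.

Measured compounds in an assay on CHO cells for displacement of a labelled ligand from prostaglandin E2 receptor EP3 subtype (Homo sapiens), read by radioligand binding; a higher number here means a weaker inhibitor, a lower number a stronger inhibitor:
- compound 1, `CC(C)C(c1ccc(-c2ccc3cccc(F)c3c2)[nH]c1=O)N1CCCCS1(=O)=O`: 14 nM
- compound 2, `CC(C)C(c1ncco1)c1ccc(-c2ccc3cccc(F)c3c2)[nH]c1=O`: 24 nM
- compound 3, `CC(C)C(Cc1nnc[nH]1)c1ccc(-c2ccc3cccc(F)c3c2)[nH]c1=O`: 10 nM

Compound 3 gives the lowest number of the three, but its step to compound 1 is within the scatter, a 1.4-fold lower number from compound 1 to compound 3 (0.15 log units; within the scatter), and only its step to compound 2 is beyond it, a 2.4-fold lower number from compound 2 to compound 3 (0.38 log units; beyond the scatter). All three compounds share the same core and differ only in the group on the saturated chain carbon bound to an aromatic carbon and a saturated chain carbon.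

Compound 4, `CC(C)C(c1ccc(-c2ccc3cccc(F)c3c2)[nH]c1=O)N1CCCCC1=O`, has not yet been measured in this assay. The change from compound 3 is 2-oxopiperidin-1-yl in place of (4H-1,2,4-triazol-3-yl)methyl on a saturated chain carbon bound to an aromatic carbon and a saturated chain carbon. The step from compound 1 to compound 3 bears on it most directly, since compound 1 also carries a six-membered non-aromatic ring on that carbon and that exchange stayed within the scatter; the step from compound 2 to compound 3 shows the largest movement seen here, and it is modest. For the measured compounds named here, no step among the measured compounds moved the number far in either direction.

Compound 4 is therefore expected to give a number close to that of compound 3, with the step of a 1.5-fold higher number from compound 3 to compound 4 (0.18 log units; within the scatter) estimated as small, most likely toward a slightly higher number. The estimate for compound 4 in this assay is 15 nM, within 6 nM to 40 nM.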

Compound 4, inhibition constant: 6.4 nM
Estimate against measurement, compound 4: 2.3-fold (0.37 log units) above, within the range that was stated.
By their numbers in this assay, from the lowest: compounds 4, 3, 1 and 2 (each within the scatter of the next, the first and the last beyond it).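

In this assay, 2-oxopiperidin-1-yl on the saturated chain carbon bound to an aromatic carbon and a saturated chain carbon stays level with (4H-1,2,4-triazol-3-yl)methyl (a 1.6-fold lower number from compound 3 to compound 4 (0.19 log units; within the scatter)), so within this pair the hydrogen-bond donor counted on the triazole group is not needed to reach this range. Compound 4 also separates from the oxazole-bearing compound (a 3.8-fold lower number from compound 2 to compound 4 (0.57 log units; beyond the scatter)) and from the other compound with a six-membered non-aromatic ring (a 2.2-fold lower number from compound 1 to compound 4 (0.34 log units; beyond the scatter)), which shows that the number can move beyond the scatter even when the ring size on this carbon stays the same. Nothing shown here accounts for these steps.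

For the compounds shown here, with only one exchange between six-membered non-aromatic rings, it remains open whether the difference between compound 1 and compound 4 follows the sulfur-containing group of compound 1 or some other feature of that exchange. Going by these compounds, it also remains open how a plain piperidin-1-yl amine, lacking the carbonyl, or a smaller 2-oxopyrrolidin-1-yl ring would behave on this carbon.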